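Cyclobutyl Replaces Hydroxypropyl on an Aminotriazolopyrimidine Core

The source may report more compounds than this note shows. Statements on the series, on what has been measured and on what is new or still open speak of the compounds shown alone.

Compound 1, `OCCCNc1nc(-c2ccccc2)nc2c1nnn2Cc1ccccc1Cl`: 33000000 nM
Compound 2, `OCCCNc1nc(-c2ccccc2)nc2c1nnn2Cc1ccccc1`: 21400000 nM
Compound 3, `OCCNc1nc(-c2ccccc2)nc2c1nnn2Cc1ccccc1`: 38000000 nM

All three compounds share one core and were tested in an assay on isolated protein for binding affinity to adenosine receptor A1 (Bos taurus); on this read-out higher numbers stand for weaker inhibition and lower numbers for stronger inhibition. Compound 1 gives 33000000 nM, and its value sits within the scatter of both compound 2 and compound 3, so none of the three can be set apart from the others. Removing the chloro, a 1.5-fold lower number from compound 1 to compound 2 (0.19 log units; within the scatter), and shortening the hydroxy-bearing chain, a 1.8-fold higher number from compound 2 to compound 3 (0.25 log units; within the scatter), both leave the numbers where they were.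

Compound 4, `Clc1ccccc1Cn1nnc2c(NC3CCC3)nc(-c3ccccc3)nc21`, differs from compound 1 in one place: cyclobutyl in place of 3-hydroxypropyl on a nitrogen on an aromatic ring. For the measured compounds named here, no measured step swaps this chain for a ring; the closest is the chain-shortening from compound 2 to compound 3, which stayed within the scatter. On that basis the step of a 1.3-fold lower number from compound 1 to compound 4 (0.12 log units; within the scatter) is expected to be small, with no clear direction, and compound 4 is estimated at 25000000 nM, with a range from 5000000 nM to 120000000 nM.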

Compound 4, inhibition constant: 24000000 nM
Compound 4: middle estimate off by 1.0-fold (0.02 log units), on the high side; measured number inside the range.
By their numbers in this assay, from the lowest: compounds 2, 4, 1 and 3 (each within the scatter of the next).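

Putting cyclobutyl in place of 3-hydroxypropyl on the nitrogen gives a 1.4-fold lower number from compound 1 to compound 4 (0.14 log units; within the scatter) in this assay. The earlier steps shown here changed the length of the chain but kept its hydroxy group, whereas this one removes the hydroxy group and the open chain together. At this position, then, an all-carbon four-membered ring with the same count of heavy atoms, and with no hydrogen-bond donor or acceptor, gives a value that cannot be told apart from that of the hydroxy-bearing chain, and no measurement is available to explain this result.

From the compounds shown here alone, whether an amine or a carboxylic acid at the end of the chain would move the number beyond the scatter remains open. The same question stands for a larger ring such as cyclohexyl on this nitrogen.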